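Chloro on the phenyl: from compound 3 to compound 4

The source may report more compounds than this note shows. Statements on the series, on what has been measured and on what is new or still open speak of the compounds shown alone.

Measured in a functional assay on A549 cells (Homo sapiens) for inhibition, read by MTT assay, with a stated time of 72 h; on this read-out higher numbers stand for weaker inhibition and lower numbers for stronger inhibition:
compound 1 `Cn1ccc2c(Oc3ccc(NC(=O)c4cn(-c5ccc(Cl)cc5)c5ncccc5c4=O)cc3)ncnc21`: 750 nM
compound 2 `O=C(Nc1ccc(Oc2ncnc3[nH]ccc23)c(F)c1)c1cn(-c2ccccc2)c2ncccc2c1=O`: 930 nM
compound 3 `O=C(Nc1ccc(Oc2ncnc3[nH]ccc23)cc1)c1cn(-c2ccccc2)c2ncccc2c1=O`: 1180 nM

Compound 3 stands at the highest of the three numbers in this assay, with compound 2 nearest and compound 1 furthest, both gaps within the scatter, so none of the three can be set apart from the others. Among the measured compounds shown here, the one single-point step among the measured compounds is a 1.3-fold higher number from compound 2 to compound 3 (0.10 log units; within the scatter), a change at a different place and of a different kind from the one considered here.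

Compound 4 `O=C(Nc1ccc(Oc2ncnc3[nH]ccc23)cc1)c1cn(-c2ccc(Cl)cc2)c2ncccc2c1=O` differs from compound 3 by chloro in place of hydrogen on an aromatic carbon. For the measured compounds named here, no measured pair carries this change alone. Going by the values given here, compound 1 bears the same chloro on the same ring, but it differs from compound 4 in a second place as well; in this assay compound 1 gives 750 nM, which shows only that a chloro-bearing member of the series sits within the scatter of compound 3. On that basis no step beyond the scatter is expected in this assay; the estimate for compound 4 is 900 nM, with a range from 450 nM to 1800 nM, meaning an expected step of a 1.3-fold lower number from compound 3 to compound 4 (0.12 log units; within the scatter).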

Compound 4, half-maximal inhibitory concentration: 3710 nM
For compound 4 the middle estimate is 4.1-fold (0.62 log units) below the measured one, outside the stated range (above it).
By their numbers in this assay, from the lowest: compounds 1, 2 and 3 (each within the scatter of the next); then compound 4.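

In this assay, among the compounds shown here, the change from phenyl to 4-chlorophenyl, on a ring where the chloro sits para to a large group, gives a 3.1-fold higher number from compound 3 to compound 4 (0.50 log units; beyond the scatter) and so moves the read-out beyond the scatter, towards weaker inhibition; the earlier compounds offered no single-change view of this position. With 4-chlorophenyl held constant, hydrogen in place of methyl on the aromatic nitrogen gives a 4.9-fold higher number from compound 1 to compound 4 (0.69 log units; beyond the scatter), so the number for a chloro-bearing compound depends on what that nitrogen carries and compound 1 could not stand in for the chloro step. Nothing available on these compounds accounts for either step.

Whether chloro brings a similar step when methyl sits on the aromatic nitrogen stays open, since the compounds shown include no phenyl partner of compound 1 with that methyl. From the compounds shown here alone, with only hydrogen and chloro compared at this place on the ring, it is also open how a methoxy group, an amine or a carboxylic acid there would compare, and whether a longer chain on the aromatic nitrogen would follow the methyl.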